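The compounds below may be only part of what the source reports. "The series", "measured", "known", "first", "only" and "open" are said of these compounds alone.

Among the three measured compounds, compound 1 `CC(C)C[C@H](N)c1cc(Cl)ccc1N1CCN(C(=O)C(C)Cc2ccc(Cl)cc2)CC1` gives 67 nM in an assay on HEK293 cells for displacement of a labelled ligand from Melanocortin receptor 4 (Homo sapiens); a higher number here means a weaker inhibitor, a lower number a stronger inhibitor. Compound 2 `CC(C)C[C@H](N)c1cc(F)ccc1N1CCN(C(=O)C(C)Cc2ccc(Cl)cc2)CC1` differs from compound 1 only by a fluoro in place of chloro on an aromatic carbon; in this assay compound 2 gives 390 nM, and that change is a 5.8-fold higher number from compound 1 to compound 2 (0.76 log units; beyond the scatter). Compound 3 `CC(C)C[C@H](N)c1cc(C(F)(F)F)ccc1N1CCN(C(=O)COc2ccc(Cl)cc2)CC1` gives 2900 nM in this assay, the highest number of the three, so it is the weakest inhibitor here, lying beyond the scatter from both compound 2 and compound 1.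

Compound 4 `CC(C)C[C@H](N)c1cc(C(F)(F)F)ccc1N1CCN(C(=O)CCC(=O)c2ccc(Cl)cc2)CC1` is the next step from compound 3. The change is ((4-chlorophenyl)carbonyl)methyl in place of 4-chlorophenoxy on a saturated chain carbon bound to a carbonyl carbon. Within the data shown here, no measured pair shows this kind of swap: the only step on record is the halogen exchange from compound 1 to compound 2, which sits on the core rather than on the chain and therefore says nothing direct about the new chain. The data are thus silent on which way this change will move this assay, and any expectation must be loose and centered near the starting point.

On that basis compound 4 is expected to give about 1500 nM, with a plausible range from 300 nM to 7000 nM. This estimate means a step of a 1.9-fold lower number from compound 3 to compound 4 (0.29 log units; within the scatter) from compound 3, not clearly beyond the scatter.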

Compound 4, inhibition constant: 820 nM
Beside the measured number, compound 4's estimate is 1.8-fold (0.26 log units) above it; measured number inside the range.
By their numbers in this assay, from the lowest: compound 1; then compound 2; then compound 4; then compound 3.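

In this assay, the chain on the amide carbonyl proves to be a place where the number responds: ((4-chlorophenyl)carbonyl)methyl in place of 4-chlorophenoxy gives a 3.5-fold lower number from compound 3 to compound 4 (0.55 log units; beyond the scatter). Among these compounds, until now the only single change on record was the halogen exchange on the core, so this is a second site where one change moves the number beyond the scatter, this time toward a stronger inhibitor, with the chlorinated aromatic ring kept in both groups. Nothing measured here gives a reason for this step.

The swap alters two things at once, the link to the ring and the length of the chain, so the compounds shown cannot separate the part played by the ketone carbonyl from that of the longer chain; a plain carbon chain or an alcohol in place of that carbonyl would pull the two apart. Going by these compounds, it also stays open whether the same swap would lower the number on a core carrying chloro or fluoro instead of trifluoromethyl, as the chains in those compounds differ from both of these.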